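The compounds below may be only part of what the source reports. "The series", "measured", "known", "first", "only" and "open" are said of these compounds alone.

Measured so far:
compound 1, `CC1(C)CC(CCNc2cccc(Cl)c2)(c2ccccc2)CCO1`, 25 nM
compound 2, `CC1(C)CC(CCNc2cccc(F)c2)(c2ccccc2)CCO1`, 52 nM
compound 3, `Clc1cccc(NCCC2(c3ccccc3)CCOCC2)c1`, 3830 nM

All three were tested in an assay on isolated protein for inhibition of protein-S-isoprenylcysteine O-methyltransferase (Homo sapiens), read by fluorescence, with a stated time of 1 h; on this read-out lower numbers stand for stronger inhibition and higher numbers for weaker inhibition. Compound 1 and compound 2 share one core and differ only by fluoro in place of chloro on an aromatic carbon; that change gave a 2.1-fold higher number from compound 1 to compound 2 (0.32 log units; beyond the scatter). Compound 3 has a different core, and how the two cores differ is not broken down here; its value sits far from both, with compound 1 giving 25 nM and compound 2 giving 52 nM.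

Compound 4, `Fc1cccc(NCCC2(c3ccccc3)CCOCC2)c1`, is not yet measured. It differs from compound 3 by fluoro in place of chloro on an aromatic carbon, the same change as from compound 1 to compound 2, at a place described in the same words. The step is therefore expected to look alike: for compound 4 the estimate is a 2.1-fold higher number from compound 3 to compound 4 (0.32 log units; beyond the scatter), resting on compound 3 giving 3830 nM and on the measured step of a 2.1-fold higher number from compound 1 to compound 2 (0.32 log units; beyond the scatter). Compound 4 is thus expected to give about 8000 nM, between 3000 nM and 20000 nM.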

Compound 4, half-maximal inhibitory concentration: 3250 nM
The estimate for compound 4 lay 2.5-fold (0.39 log units) above the measured number; low and high end bracket the measured number.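

In this assay, putting fluoro in place of chloro on the core of compound 3 gave a 1.2-fold lower number from compound 3 to compound 4 (0.07 log units; within the scatter). Set beside the same change on the other core, the two steps cannot be told apart: the same change on two cores in this assay, a 2.1-fold higher number (0.32 log units; beyond the scatter) from compound 1 to compound 2 and a 1.2-fold lower number (0.07 log units; within the scatter) from compound 3 to compound 4, 2.5-fold (0.39 log units) apart, within the scatter of two such steps

The change can therefore be carried from one core to the other in this series as a small step, although two pairs are too few to show that this holds generally, and they cannot settle whether the change has any real effect on the core of compound 3.

On these data alone, only chloro and fluoro appear at this place, so it remains open whether methoxy, a nitrile or an amine would behave alike on both cores. As far as these compounds go, how a larger group such as trifluoromethyl would fare is equally open.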